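The source may report more compounds than this note shows. Statements on the series, on what has been measured and on what is new or still open speak of the compounds shown alone.

In an assay on HEK293 cells for positive allosteric modulation of metabotropic glutamate receptor 5 (Homo sapiens), read by FLIPR, with a stated time of 1 h (a higher number here means that more compound is needed for the effect, a lower number that less compound is needed), compound 2 `O=C(C1CCC(F)(F)CC1)N1CCc2nc(C#Cc3ccccc3)sc2C1` gives 70 nM. Compound 1 `Fc1cccc(C#Cc2nc3c(s2)CN(C2CCOC2)CC3)c1` reaches only the limit of this assay, > 10000 nM, which is not a number but the point beyond which the test stops counting (the limit of > 10000 nM in this assay, at which 1 of the 2 values shown sits). Among the compounds with values here, compound 2 therefore holds the only real number in this set, and there is no second measured compound close enough in structure to show how large a single change tends to be here.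

Compound 3 `O=C(N1CCC(F)CC1)N1CCc2nc(C#Cc3ccccc3)sc2C1` differs from compound 2 in one place: 4-fluoropiperidin-1-yl in place of 4,4-difluorocyclohexyl on a carbonyl carbon. The carbonyl that was a ketone now joins two nitrogen atoms and becomes a urea, and one of the two fluorines is gone. Without a measured step of this kind to lean on, the expected shift from compound 2 to compound 3 is a 2.1-fold higher number from compound 2 to compound 3 (0.33 log units; beyond the scatter), a change not clearly beyond the usual scatter. Compound 3 is thus estimated at 150 nM, with a likely range from 40 nM to 600 nM.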

Compound 3, half-maximal effective concentration: 74 nM
Beside the measured number, compound 3's estimate is 2.0-fold (0.31 log units) above it; the range from low to high includes it.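

In this assay, placing 4-fluoropiperidin-1-yl on the carbonyl carbon in place of 4,4-difluorocyclohexyl gives a 1.1-fold higher number from compound 2 to compound 3 (0.02 log units; within the scatter), so the two compounds cannot be told apart in this test. Within the data shown here, this is the first step in the set that can be read, and it shows that this position tolerates a swap in which the carbonyl comes to join two nitrogen atoms, the ring gains a nitrogen and one fluorine is lost. Nothing measured here gives a reason for this result.

Several things differ at once in this step, and the compounds shown do not separate the ring nitrogen from the number of fluorines. They also leave open how this position responds to a piperidine without fluorine, a morpholine or a longer chain.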